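Hydroxy in place of hydrogen on compound 1

This account rests on a few compounds, and the source may have more. Where it says the series, first, only, none or still open, it means among the compounds named here.

Compound 1 `Cc1c(C(=O)N/N=C/c2ccccc2)no[n+]1[O-]` is known in an ADME assay on J774.1 cells (Mus musculus) for cytotoxicity, read by MTT assay, with a stated time of 48 h (on this read-out lower numbers stand for stronger inhibition and higher numbers for weaker inhibition), only as a limit. In this assay compound 1 gives > 400000 nM, a limit of the assay and not a number. Compound 1 sits at the limit of > 400000 nM in this assay, at which 2 of the 3 values shown sit. Compound 2 `CC(=O)Nc1ccc(/C=N/NC(=O)c2no[n+]([O-])c2C)cc1`, carrying acetamido in place of hydrogen on an aromatic carbon, gives 235000 nM in this assay, and the step of an at least 1.7-fold lower number from compound 1 to compound 2 (0.23 log units; that floor lies within the scatter) stays inside the scatter. Compound 3 `Cc1c(C(=O)N/N=C/c2cccc(O)c2)no[n+]1[O-]`, with hydroxy in place of hydrogen on an aromatic carbon, is again a limit. In this assay compound 3 gives > 400000 nM. The step that the two limits leave unreadable from compound 1 to compound 3 is thus not readable.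

Compound 4 `Cc1c(C(=O)N/N=C/c2ccccc2O)no[n+]1[O-]` differs from compound 1 by hydroxy in place of hydrogen on an aromatic carbon. Within the data shown here, the only hydroxy step in hand, a step that the two limits leave unreadable from compound 1 to compound 3, shows nothing beyond the limit, and the acetamido step lies within the scatter, so no step beyond the scatter is expected in this assay in either direction. Compound 4 is therefore expected to give 450000 nM in this assay, between 200000 nM and 1000000 nM, most likely reported as a limit once more. The expected step is a step that the limit leaves unreadable from compound 1 to compound 4.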

Compound 4, half-maximal inhibitory concentration: 246000 nM
The estimate for compound 4 lay 1.8-fold (0.26 log units) above the measured number; measured number inside the range.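

In this assay, among these compounds, hydroxy ortho to a large group gives the first hydroxy compound with a number rather than a limit: compound 4 gives 246000 nM. The change reads as an at least 1.6-fold lower number from compound 1 to compound 4 (0.21 log units; that floor lies within the scatter), so it has only a floor, and that floor does not clear the scatter. Compound 3 gives > 400000 nM, which is a limit of the assay and not a number, so the step to it cannot be read and the two hydroxy compounds share no measured scale: the limit of > 400000 nM in this assay, at which 2 of the 4 values shown sit.

Still open, going by these compounds, is how far compound 4 truly lies from compound 1, as the limit on compound 1 fixes only the floor of that step. Also open, on these data alone, is whether the number depends on hydroxy itself, since a methoxy group or an amine on the same aromatic carbon would test that.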